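The source may report more compounds than this note shows. Statements on the series, on what has been measured and on what is new or still open speak of the compounds shown alone.

Measured compounds:
- compound 1, `CCCCn1ccc(-c2ccc(Oc3ccnc(C)c3)c(Cl)c2)c(C#N)c1=O`, 245%
- compound 2, `CCCCn1ccc(-c2ccc(Oc3ccnc(C)c3)cc2Cl)c(C#N)c1=O`, 187%
- compound 3, `CCCCn1ccc(-c2ccc(Oc3ccnc(C)c3)c(F)c2)c(C#N)c1=O`, 233%

Of the compounds shown here, three have been measured in a functional assay on CHO cells for positive allosteric modulation of metabotropic glutamate receptor 2 (Homo sapiens), read by scintillation counting and GTPgammaS binding, with a stated time of 30 min; on this read-out higher numbers stand for larger maximal responses and lower numbers for smaller maximal responses. Compound 1 gives 245%, compound 3 gives 233%, and compound 2 gives 187%, the lowest of the three. Compounds 1 and 2 share the same atoms joined differently; the difference between the two cores is not broken down here. One change is seen directly: from compound 1 to compound 3, (fluoro in place of chloro on an aromatic carbon), and this gave a number 12 percentage points lower from compound 1 to compound 3 (beyond the scatter).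

Compound 4, `CCCCn1ccc(-c2ccc(Oc3ccnc(C)c3)cc2F)c(C#N)c1=O`, has not yet been measured. It differs from compound 2 by fluoro in place of chloro on an aromatic carbon. This is the same kind of change as that from compound 1 to compound 3, not the same one: in compound 3 the new group sits ortho to a (2-methylpyridin-4-yl)oxy group and meta to a large group, whereas in compound 4 it sits ortho to a large group and meta to a (2-methylpyridin-4-yl)oxy group. Resting only on the one observed step, a number 12 percentage points lower from compound 1 to compound 3 (beyond the scatter), a similarly modest downward step is expected from compound 2 to compound 4 in this assay, namely a number 12 percentage points lower from compound 2 to compound 4 (beyond the scatter). Since compound 2 starts from 187%, compound 4 is estimated to reach 175%, most likely between 150% and 200%.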

Compound 4, largest response reached (Emax), in percent of the reference or control that the assay uses: 232%
For compound 4 the middle estimate is 57 percentage points below the measured one; the measured number lies above the stated range.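

Where the fluoro sits ortho to a large group and meta to a (2-methylpyridin-4-yl)oxy group, fluoro in place of chloro gave a number 45 percentage points higher from compound 2 to compound 4 (beyond the scatter). Set beside the earlier step, this shows that in this assay the change kept neither its size nor its direction when carried from one core to the other: the same change on two cores in this assay, a number 12 percentage points lower (beyond the scatter) from compound 1 to compound 3 and a number 45 percentage points higher (beyond the scatter) from compound 2 to compound 4, 57 percentage points apart, beyond the scatter of two such steps The result warns against reading the step on one of these cores as a guide to the step on the other, but it rests on only two pairs of compounds, so it does not show why the two steps part, nor what the same change would do on any further core in the series.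

All four compounds carry the same butyl chain, nitrile and (2-methylpyridin-4-yl)oxy group, so the compounds shown leave open whether the two steps would stay this far apart with a longer chain in place of the butyl chain or with an amide in place of the nitrile. As far as these compounds go, only chloro and fluoro appear on the six-membered carbon ring, and what a methyl or methoxy group would do there also remains open.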